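Moving the fluorine and nitrogen on the pyridine amide

The compounds below may be only part of what the source reports. "The series", "measured", "known", "first", "only" and "open" are said of these compounds alone.

Values so far in a physicochemical assay for solubility, measured as kinetic solubility, with a stated time of 1 h, at pH 7.4 (a higher number here means a more soluble compound, a lower number a less soluble compound), are these
Compound 1 `O=C(NC1=NN(c2ccc(Cl)c(Cl)c2)CC1)c1cccnn1` gives 67000 nM here
Compound 2 `O=C(NC1=NN(c2ccc(Cl)c(Cl)c2)CC1)c1cccnc1F` gives 13000 nM here

Compound 2 stands lower of the two, at 13000 nM on this read-out. Compound 3 `O=C(NC1=NN(c2ccc(Cl)c(Cl)c2)CC1)c1ccncc1F` has the same atoms joined differently (3-fluoropyridin-4-yl in place of 2-fluoropyridin-3-yl on a carbonyl carbon), with 3-fluoropyridin-4-yl in place of 2-fluoropyridin-3-yl on a carbonyl carbon. Within the data shown here, the only measured step (a 5.2-fold lower number from compound 1 to compound 2 (0.71 log units; beyond the scatter)) was modest and replaced pyridazin-3-yl, so it gives no direct guide to this swap. The expected step (a 1.4-fold higher number from compound 2 to compound 3 (0.14 log units; within the scatter)) is small, slightly upward and within the scatter. Compound 3 is therefore estimated at 18000 nM in this assay with 7000 nM to 45000 nM as the expected range.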

Compound 3, solubility: 36000 nM
Beside the measured number, compound 3's estimate is 2.0-fold (0.30 log units) below it, within the range that was stated.
By their numbers in this assay, from the lowest: compound 2; then compounds 3 and 1 (each within the scatter of the next).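

On the carbonyl carbon, rearranging the same atoms moves the read-out in this assay: 3-fluoropyridin-4-yl in place of 2-fluoropyridin-3-yl gives a 2.8-fold higher number from compound 2 to compound 3 (0.44 log units; beyond the scatter), so the placing of the ring atoms counts here, not only their kind. 3-Fluoropyridin-4-yl in place of pyridazin-3-yl gives a 1.9-fold lower number from compound 1 to compound 3 (0.27 log units; within the scatter), so that pair cannot be told apart, though the 2-fluoropyridin-3-yl swap could. No evidence given here accounts for these differences.

Left open is how a ring bearing an amine or a methoxy group would read on this carbonyl carbon. Also open, going by these compounds, is whether the step between the two fluoropyridines would hold with other groups on the shared core.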